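Aryl amide in place of a pentyl chain

A few compounds are considered here, and "the series" means these few. Any claim that something is new, unique, unknown or untested is made for them only; others in the source may bear on it.

Compound 1, `CCCCCC(=O)NCCCN1CCN(CCCNc2ccnc3cc(Cl)ccc23)CC1`: "not determined" (no result reported) in an ADME assay on L6 cells (Rattus norvegicus) for cytotoxicity; on this read-out lower numbers stand for stronger inhibition and higher numbers for weaker inhibition.
Compound 2, `NC(=O)c1ccc(C(=O)NCCCN2CCN(CCCNc3ccnc4cc(Cl)ccc34)CC2)cc1`: "not determined" (no result reported) in this assay.
Compound 3, `O=C(CCCOc1ccccc1)NCCCN1CCN(CCCNc2ccnc3cc(Cl)ccc23)CC1`: 9300 nM in this assay.

Compound 1 stands without a number in this assay, and compound 2 is likewise without one; only compound 3 carries a measured value. Going by the values given here, no step between two measured compounds can therefore be drawn. Compound 4, `O=C(NCCCN1CCN(CCCNc2ccnc3cc(Cl)ccc23)CC1)c1ccc(Cl)c([N+](=O)[O-])c1`, differs from compound 1 by 4-chloro-3-nitrophenyl in place of pentyl on a carbonyl carbon. Among the compounds with values here, the change puts an aromatic amide on the shared core, and compound 3, the one measured compound, also carries an aromatic group in its amide side chain and gives 9300 nM in this assay. The step from compound 1 to compound 4 is therefore expected to be small in this assay, if any, with no direction beyond the scatter. Compound 4 is estimated at 7000 nM, between 1800 nM and 28000 nM.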

Compound 4, half-maximal inhibitory concentration: 11300 nM
Compound 4: middle estimate off by 1.6-fold (0.21 log units), on the low side; measured number inside the range.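

In this assay, 4-chloro-3-nitrophenyl in place of 3-phenoxypropyl on a carbonyl carbon gives a 1.2-fold higher number from compound 3 to compound 4 (0.08 log units; within the scatter). On this read-out, the two groups are therefore not told apart at this position. Compound 1 has no number, so the step from its pentyl group cannot be read, and no measurement shown gives a cause for the result. From the compounds shown here alone, whether a longer chain, or a phenyl ring carrying an amine or a carboxylic acid, on this carbonyl carbon would move the number beyond the scatter stays open.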